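Trifluoromethyl on the Benzyl Arm of Compound 1

The source may report more compounds than this note shows. Statements on the series, on what has been measured and on what is new or still open speak of the compounds shown alone.

Compound 1 `Cc1cc(N2CC[C@@H](C)[C@@H](N(C)c3ncnc4[nH]ccc34)C2)n2nc(SCc3ccccc3)nc2n1` gives 14400 nM in a functional assay on BGC-823 cells (Homo sapiens) for inhibition, read by MTT assay, with a stated time of 72 h (a higher number here means a weaker inhibitor, a lower number a stronger inhibitor), the lowest of the three numbers available. Its nearest neighbour is compound 3 `Cc1cc(N2CC[C@@H](C)[C@@H](N(C)c3ncnc4[nH]ccc34)C2)n2nc(SCc3cc(Cl)ccc3Cl)nc2n1`, which in this assay gives 18900 nM; the step of a 1.3-fold higher number from compound 1 to compound 3 (0.12 log units; within the scatter) stays within the scatter. Furthest is compound 2 `Cc1cc(N2CC[C@@H](C)[C@@H](N(C)c3ncnc4[nH]ccc34)C2)n2ncnc2n1`, which in this assay gives 67400 nM; here a 4.7-fold higher number from compound 1 to compound 2 (0.67 log units; beyond the scatter), a modest step beyond the scatter, and a 3.6-fold lower number from compound 2 to compound 3 (0.55 log units; beyond the scatter) shows the return once a benzylsulfanyl arm is restored.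

Compound 4 `Cc1cc(N2CC[C@@H](C)[C@@H](N(C)c3ncnc4[nH]ccc34)C2)n2nc(SCc3ccc(C(F)(F)F)cc3)nc2n1` has not yet been measured. It differs from compound 1 by trifluoromethyl in place of hydrogen on an aromatic carbon.

Two of the measured steps bear on this. The step from compound 1 to compound 3 alters the same phenyl ring and falls within the scatter, whereas the step from compound 1 to compound 2, which removes the whole benzylsulfanyl group, is the only one beyond it. A change confined to an aromatic carbon of the phenyl ring, with the benzylsulfanyl kept, is therefore expected to leave the number close to where compound 1 stands. Compound 4 is expected to give about 15000 nM in this assay, within a range of 7000 nM to 32000 nM. The expected step of a 1.0-fold higher number from compound 1 to compound 4 (0.02 log units; within the scatter) is thus estimated to lie within the scatter.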

Compound 4, half-maximal inhibitory concentration: 23300 nM
For compound 4 the middle estimate is 1.6-fold (0.19 log units) below the measured one, within the range that was stated.
By their numbers in this assay, from the lowest: compounds 1, 3 and 4 (each within the scatter of the next); then compound 2.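

Trifluoromethyl on an aromatic carbon of the phenyl ring, para to a large group, gives a 1.6-fold higher number from compound 1 to compound 4 (0.21 log units; within the scatter) in this assay, so this position carries that group with no step beyond the scatter. Compared with the other substituted arm, the change gives a 1.2-fold higher number from compound 3 to compound 4 (0.09 log units; within the scatter), and the 4-(trifluoromethyl)phenyl and 2,5-dichlorophenyl arms therefore cannot be told apart in this assay. Set against the compound without the arm, the (4-(trifluoromethyl)benzyl)sulfanyl group gives a 2.9-fold lower number from compound 2 to compound 4 (0.46 log units; beyond the scatter), making this the third arm, after benzylsulfanyl and (2,5-dichlorobenzyl)sulfanyl, whose step to hydrogen lies beyond the scatter, with no compound shown going against this.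

Going by these compounds, whether an amine or a carboxylic acid on this phenyl ring, or a longer chain in place of the benzyl link to sulfur, would move the number beyond the scatter from compound 1 remains open. Nothing among the data shown speaks to what lies behind these steps.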